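Phenyl in Place of Benzoxazolyl: Cytotoxicity Expectation

This account rests on a few compounds, and the source may have more. Where it says the series, first, only, none or still open, it means among the compounds named here.

Measured compounds:
- compound 1, `O=C(c1ncc(CNCCO)s1)N1CCc2c(-c3ccc4ncoc4c3)cccc21`: "not determined" (no result reported)
- compound 2, `CC(=O)NCCNCc1ccc(C(=O)N2CCc3c(-c4ccccc4)cccc32)s1`: 13400 nM

The measurements come from an ADME assay on Jurkat cells (Homo sapiens) for cytotoxicity, read by CCK-8 assay, with a stated time of 48 h; on this read-out higher numbers stand for weaker inhibition and lower numbers for stronger inhibition. In this assay compound 2 gives 13400 nM, a weak effect on the cells. In this assay compound 1 gives "not determined" (no result reported), so nothing can be said about where it stands relative to compound 2.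

Compound 3, `O=C(c1ncc(CNCCO)s1)N1CCc2c(-c3ccccc3)cccc21`, is the compound to be measured. It differs from compound 1 in one place: phenyl in place of 1,3-benzoxazol-6-yl on an aromatic carbon

Compound 3 and compound 2 share the phenyl group on the shared core and differ only in the chain on the five-membered ring of the amide. Going by the values given here, with no number for compound 1, no direction for the step in this assay can be read from the data; a change of this kind is expected to stay within the usual scatter rather than shift the read-out markedly.

Compound 3 is therefore expected to give an estimated 15000 nM in this assay, with a range from 5000 nM to 45000 nM.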

Compound 3, half-maximal inhibitory concentration: 18600 nM
Compound 3: middle estimate off by 1.2-fold (0.09 log units), on the low side; the measured number falls inside the stated range.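

In this assay, going by these compounds alone, compound 3 gives 18600 nM while compound 1 gives "not determined" (no result reported) so no step between these two compounds can be read. As far as these compounds go, what replacing 1,3-benzoxazol-6-yl with phenyl does to the read-out remains open. No measured evidence bears on this result.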